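A few compounds are considered here, and "the series" means these few. Any claim that something is new, unique, unknown or untested is made for them only; others in the source may bear on it.

In an in vitro ADME assay on microsomes from liver (Homo sapiens) for metabolic stability, read by HPLC, with a stated time of 4 h (a higher number here means faster removal of the compound, a lower number slower removal), two compounds on a shared core have been measured so far. Compound 1 `CCOC(=O)c1c(-c2cccc(-c3ccccc3)c2)[nH]c2cc(OC)ccc2c1=O` gives 5 mL.min-1.g-1 and compound 2 `CCOC(=O)c1c(-c2cccc(OC)c2)[nH]c2cc(OC)ccc2c1=O` gives 5.7 mL.min-1.g-1 so that compound 2 stands level with compound 1 within the scatter. Compound 3 `CCOC(=O)c1c(-c2cccc(OCC)c2)[nH]c2cc(OC)ccc2c1=O` has not yet been measured and differs from compound 2 by methyl in place of hydrogen on a saturated chain carbon bound to an oxygen on an aromatic ring in the form of methyl in place of hydrogen on a saturated chain carbon bound to an oxygen on an aromatic ring, which reads as methoxy to ethoxy. Going by the values given here, the only guide is a 1.1-fold higher number from compound 1 to compound 2 (0.06 log units; within the scatter) for methoxy in place of phenyl on an aromatic carbon, a step that stayed within the scatter and involved the same methoxy group. No change beyond the scatter is therefore expected, with at most a slight rise. A step of a 1.1-fold higher number from compound 2 to compound 3 (0.06 log units; within the scatter) is the estimate. For compound 3 the expected value is 6.5 mL.min-1.g-1 with an estimated range from 3.5 mL.min-1.g-1 to 12 mL.min-1.g-1 as the likely span.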

Compound 3, intrinsic clearance in microsomes: 5.7 mL.min-1.g-1
The estimate for compound 3 lay 1.1-fold (0.06 log units) above the measured number, within the range that was stated.
By their numbers in this assay, from the lowest: compounds 1, 2 and 3 (each within the scatter of the next).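

In this assay, methyl in place of hydrogen on a saturated chain carbon bound to an oxygen on an aromatic ring, which turns methoxy into ethoxy, gives no change at the digits printed from compound 2 to compound 3 (within the scatter) for this change on the shared core. The change from phenyl to ethoxy gives a 1.1-fold higher number from compound 1 to compound 3 (0.06 log units; within the scatter) and so also stays inside the usual scatter, which leaves phenyl, methoxy and ethoxy level at this position across compound 1, compound 2 and compound 3. Nothing measured here accounts for this levelness.

Going by these compounds, whether a longer chain on the same oxygen would also stay level remains open. So does the outcome for an amine or a carboxylic acid at this position, since all three groups shown carry neither.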